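Pyridazinone amides on a shared core: step to compound 3

The source may hold more compounds than are shown below. What is called first, only, known or untested is meant among the compounds shown, and "the series" means these compounds.

Measured so far in a functional assay on PC-3 cells (Homo sapiens) for cytotoxicity, read by MTT assay, with a stated time of 72 h; a lower number here means a stronger inhibitor, a higher number a weaker inhibitor:
compound 1 `Cc1cc(=O)n(-c2ccc(F)cc2)nc1C(=O)Nc1ccc(Oc2ncnc3[nH]ccc23)c(F)c1` gives 17300 nM
compound 2 `Cc1ccc(-n2nc(C(=O)Nc3ccc(Oc4ncnc5[nH]ccc45)c(F)c3)c(C)cc2=O)cc1` gives 20400 nM

Compound 2 holds the highest of the two numbers; the only other point, compound 1, sits within the scatter of it, as the step of a 1.2-fold higher number from compound 1 to compound 2 (0.07 log units; within the scatter) shows. Compound 3 `Cc1ccc(-n2nc(C(=O)Nc3ccc(Oc4ncnc5c4ccn5C)c(F)c3)c(C)cc2=O)cc1` differs from compound 2 by methyl in place of hydrogen on an aromatic nitrogen. Within the data shown here, no measured step touches this part of the shared core, so the one known step gives no guide here. The expectation is therefore no step beyond the scatter, with a wide range. Compound 3 is estimated at 25000 nM (range 9000 nM to 70000 nM), a step of a 1.2-fold higher number from compound 2 to compound 3 (0.09 log units; within the scatter) expected.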

Compound 3, half-maximal inhibitory concentration: 50500 nM
The estimate for compound 3 lay 2.0-fold (0.31 log units) below the measured number, and the stated range covers the measured number.
By their numbers in this assay, from the lowest: compounds 1 and 2 (each within the scatter of the next); then compound 3.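

Methyl in place of hydrogen on the aromatic nitrogen gives the first step beyond the scatter in this series in this assay, a 2.5-fold higher number from compound 2 to compound 3 (0.39 log units; beyond the scatter). This position on the shared core therefore responds to substitution, which the change on the aromatic carbon, a 1.2-fold higher number from compound 1 to compound 2 (0.07 log units; within the scatter), did not show. Nothing shown here accounts for this step.

Open, going by these compounds, is whether an ethyl group or a longer chain ending in an amine on this nitrogen would raise the number further. Also open, on these data alone, is whether the same methyl step holds with the fluoro group of compound 1.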